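The compounds below may be only part of what the source reports. "The series", "measured", "known", "first", "only" and "open" are said of these compounds alone.

In a functional assay (aorta) for inhibition, with Rattus norvegicus as the target (a higher number here means a weaker inhibitor, a lower number a stronger inhibitor), compound 1 `C/N=C(\S)[C@]1(c2ccc(Cl)c(Cl)c2)CCCC[S+]1[O-]` gives 300 nM, compound 2 `C/N=C(\S)[C@]1(c2ccc(Cl)cc2)CCCC[S+]1[O-]` gives 2800 nM and compound 3 `C/N=C(\S)[C@]1(c2ccc3ccccc3c2)CCCC[S+]1[O-]` gives 2000 nM. Compound 2 thus stands within the scatter of compound 3, while its number is clearly higher than that of compound 1. Compound 4 `C/N=C(\S)[C@]1(c2ccc(-c3ccccc3)cc2)CCCC[S+]1[O-]` has phenyl in place of chloro on an aromatic carbon, (phenyl in place of chloro on an aromatic carbon). Among the compounds with values here, the only measured step, a 9.3-fold higher number from compound 1 to compound 2 (0.97 log units; beyond the scatter), is a different change, so its size does not carry over directly. It shows only that one chloro can shift the number beyond the scatter. In this assay, no clear step is therefore expected, and the estimate is a 1.1-fold higher number from compound 2 to compound 4 (0.03 log units; within the scatter), with the direction uncertain. Compound 4 is estimated at 3000 nM, with an expected range from 800 nM to 10000 nM.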

Compound 4, concentration for 90% inhibition: 12000 nM
Compound 4: the middle estimate sits 4.0-fold (0.60 log units) below what was measured; the measured number lies above the stated range.
By their numbers in this assay, from the lowest: compound 1; then compounds 3 and 2 (each within the scatter of the next); then compound 4.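

In this assay, phenyl in place of chloro on an aromatic carbon gives a 4.3-fold higher number from compound 2 to compound 4 (0.63 log units; beyond the scatter). Within the data shown here, the earlier step concerned a different chloro, so this is the first sign that the group at this position, para to a large group, itself moves the number, with the six-carbon ring going with a weaker inhibitor. No measured evidence on the compounds explains this shift. As far as these compounds go, whether fluoro, methoxy or an amine at this position would keep, lower or raise the number remains open.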